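The source may hold more compounds than are shown below. What is called first, only, known or untested is meant among the compounds shown, and "the series" means these compounds.

Compound 1 `O=C(/C=C/c1cccc2ccccc12)c1cccc(NC(=O)c2cc(-c3ccncc3)n[nH]2)c1` gives 64500 nM in a functional assay, read by spectrophotometry, tested at 100 uM (a lower number here means a stronger inhibitor, a higher number a weaker inhibitor), and stands as the higher of the two numbers measured, its nearest neighbour compound 2 `COc1ccc(/C=C/C(=O)c2cccc(NC(=O)c3cc(-c4ccncc4)n[nH]3)c2)cc1` giving 38400 nM in this assay. The step of a 1.7-fold lower number from compound 1 to compound 2 (0.23 log units; within the scatter) is the only one measured and bears directly on compound 3 `COc1ccccc1/C=C/C(=O)c1cccc(NC(=O)c2cc(-c3ccncc3)n[nH]2)c1`, which differs from compound 1 by 2-methoxyphenyl in place of naphthalen-1-yl on a double-bonded chain carbon bound to a double-bonded chain carbon. Since the related change produced a 1.7-fold lower number from compound 1 to compound 2 (0.23 log units; within the scatter), no step beyond the scatter is expected here either. Compound 3 is therefore expected at 45000 nM in this assay, within 20000 nM to 100000 nM. The step this estimate implies is a 1.4-fold lower number from compound 1 to compound 3 (0.16 log units; within the scatter).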

Compound 3, half-maximal inhibitory concentration: 41700 nM
Compound 3: middle estimate off by 1.1-fold (0.03 log units), on the high side; the measured number falls inside the stated range.
By their numbers in this assay, from the lowest: compounds 2, 3 and 1 (each within the scatter of the next).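

In this assay, 2-methoxyphenyl in place of naphthalen-1-yl gives a 1.5-fold lower number from compound 1 to compound 3 (0.19 log units; within the scatter) and remains within the scatter, as does 2-methoxyphenyl in place of 4-methoxyphenyl, with a 1.1-fold higher number from compound 2 to compound 3 (0.04 log units; within the scatter). At this place on a double-bonded chain carbon, the data therefore separate neither the two methoxyphenyl groups from each other nor either of them from naphthalen-1-yl. Nothing available explains why these three groups read alike.

On these data alone, it remains open whether any group here can move the number beyond the scatter, such as an amine or a carboxylic acid on the phenyl ring. Changes elsewhere on the shared core also remain open.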